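This account rests on a few compounds, and the source may have more. Where it says the series, first, only, none or still open, it means among the compounds named here.

Measured in a functional assay on HeLa cells (Homo sapiens) for antiproliferative activity, read by MTT assay, with a stated time of 72 h; on this read-out lower numbers stand for stronger inhibition and higher numbers for weaker inhibition:
compound 1 `CNc1nc(-c2cc(OC)c(OC)c(OC)c2)c(-c2ccc3ccccc3c2)s1`: 128 nM
compound 2 `CNc1nc(-c2cc(OC)c(OC)c(OC)c2)c(-c2ccc(C)cc2)s1`: 69.1 nM
compound 3 `COc1cc(-c2nc(N(C)C)sc2-c2ccc3ccccc3c2)cc(OC)c1OC`: 1400 nM

Of these three, compound 3 has the highest number, 1400 nM. Compound 4 `COc1cc(-c2nc(N(C)C)sc2-c2ccc(C)cc2)cc(OC)c1OC` differs from it in one place: 4-methylphenyl in place of naphthalen-2-yl on an aromatic carbon. Compound 2 carries the entering group and compound 1 the leaving one. Compound 1 at 128 nM and compound 2 at 69.1 nM lie within the usual scatter of each other. For the measured compounds named here, the one large measured step, an 11-fold higher number from compound 1 to compound 3 (1.04 log units; beyond the scatter), concerns the nitrogen, which does not change here. In this assay, therefore, no step beyond the scatter is expected, with at most a slight drift to a lower number. The expected step is a 1.6-fold lower number from compound 3 to compound 4 (0.19 log units; within the scatter). The estimate for compound 4 is 900 nM, with an expected range of 250 nM to 3000 nM.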

Compound 4, half-maximal inhibitory concentration: 4140 nM
Compound 4: the middle estimate sits 4.6-fold (0.66 log units) below what was measured; measured number above the stated range.
By their numbers in this assay, from the lowest: compounds 2 and 1 (each within the scatter of the next); then compound 3; then compound 4.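

In this assay, replacing naphthalen-2-yl with 4-methylphenyl matters once the nitrogen bears a second methyl, giving a 3.0-fold higher number from compound 3 to compound 4 (0.47 log units; beyond the scatter), whereas compound 1 and compound 2 lie within the scatter of each other. The added methyl on the nitrogen also costs more with 4-methylphenyl at this position, with a 60-fold higher number from compound 2 to compound 4 (1.78 log units; beyond the scatter), so the two places do not act independently: the same change on two cores in this assay, an 11-fold higher number (1.04 log units; beyond the scatter) from compound 1 to compound 3 and a 60-fold higher number (1.78 log units; beyond the scatter) from compound 2 to compound 4, 5.5-fold (0.74 log units) apart, beyond the scatter of two such steps. The compounds shown leave open whether an ethyl chain on the nitrogen would follow the same course. They also leave open how an unsubstituted phenyl at this carbon would behave on either core.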